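Replacing 4-(dimethylamino)phenyl with 3,4-dimethoxyphenyl

The source may hold more compounds than are shown below. What is called first, only, known or untested is meant among the compounds shown, and "the series" means these compounds.

In a functional assay on KB cells (Homo sapiens) for inhibition, read by sulforhodamine B assay (on this read-out higher numbers stand for weaker inhibition of growth and lower numbers for stronger inhibition of growth), compound 3 (`CN(C)c1ccc(-c2ccc(-c3ccc(-c4nc5c(O)cccc5[nH]4)cc3)cc2)cc1`) gives 4200 nM. Compound 2 (`Oc1cccc2[nH]c(-c3ccc(-c4ccc(-c5ccc(C(F)(F)F)cc5)cc4)cc3)nc12`) gives 4320 nM, level with it within the scatter, while compound 1 (`COc1ccc(-c2ccc(-c3ccc(-c4nc5ccccc5[nH]4)cc3)cc2)cc1OC`) stands higher at 9250 nM.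

Compound 4 (`COc1ccc(-c2ccc(-c3ccc(-c4nc5c(O)cccc5[nH]4)cc3)cc2)cc1OC`) carries 3,4-dimethoxyphenyl in place of 4-(dimethylamino)phenyl on an aromatic carbon. Going by the values given here, the one measured step at this place is a 1.0-fold lower number from compound 2 to compound 3 (0.01 log units; within the scatter), which stays within the scatter. Compound 1 carries the same 3,4-dimethoxyphenyl on a core that is not the same, and its number of 9250 nM leans slightly upward. Only a small move toward a higher number is therefore expected, not one beyond the scatter. The estimated step is a 1.2-fold higher number from compound 3 to compound 4 (0.08 log units; within the scatter). For compound 4 the expected value is 5000 nM, with an estimated range of 2300 nM to 10000 nM.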

Compound 4, concentration for 50% growth inhibition: 2710 nM
The estimate for compound 4 lay 1.8-fold (0.27 log units) above the measured number, and the stated range covers the measured number.
By their numbers in this assay, from the lowest: compounds 4, 3 and 2 (each within the scatter of the next); then compound 1.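

In this assay, 3,4-dimethoxyphenyl reads level with the other groups at this place, both against 4-(dimethylamino)phenyl (a 1.5-fold lower number from compound 3 to compound 4 (0.19 log units; within the scatter)) and against 4-(trifluoromethyl)phenyl (a 1.6-fold lower number from compound 2 to compound 4 (0.20 log units; within the scatter)). Going by these compounds alone, the new compound also gives the first single change beyond the scatter, hydroxy in place of hydrogen on an aromatic carbon (a 3.4-fold lower number from compound 1 to compound 4 (0.53 log units; beyond the scatter)). No measurement shown here accounts for either finding.

On these data alone, whether the hydroxy step holds with the other two groups remains open. So does how a morpholine or a carboxylic acid would read at this place.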